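Replacing Bromo with Phenyl in a KG-1 Cytotoxicity Series

The source may report more compounds than this note shows. Statements on the series, on what has been measured and on what is new or still open speak of the compounds shown alone.

Of the compounds shown here, three have been measured in a functional assay on KG-1 cells (Homo sapiens) for cytotoxicity, read by luminescence and CellTiter-Glo, with a stated time of 3 days; a higher number here means a weaker inhibitor, a lower number a stronger inhibitor. Compound 1 `COc1ccc(O)c(C(=O)Nc2ccc(C#N)cc2)c1` gave only a limit, > 10000 nM. Compound 2 `O=C(Nc1cc(C(F)(F)F)cc(C(F)(F)F)c1)c1cc(Br)c(-c2ccccc2)cc1O`, which carries both a phenyl and a bromo group, gave 300 nM. Compound 3 `O=C(Nc1cc(C(F)(F)F)cc(C(F)(F)F)c1)c1ccc(Br)cc1O` gave 830 nM, the higher of the two actual numbers, and its gap to compound 2 lies beyond the usual scatter.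

The next compound, compound 4 `O=C(Nc1cc(C(F)(F)F)cc(C(F)(F)F)c1)c1ccc(-c2ccccc2)cc1O`, has phenyl in place of bromo on an aromatic carbon, meta to a hydroxy group and para to a large group: phenyl in place of bromo on an aromatic carbon. Among the compounds with values here, no two measured compounds differ in only one place, so the effect of this exchange has not been observed directly. The closest guide is compound 2, at 300 nM, which also holds a phenyl group. The expected change is a 2.1-fold lower number from compound 3 to compound 4 (0.32 log units; beyond the scatter), a modest shift towards stronger inhibition, close to the edge of the scatter. For compound 4 the estimated value in this assay is 400 nM, with an expected range of 130 nM to 1300 nM.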

Compound 4, half-maximal inhibitory concentration: 860 nM
Compound 4: middle estimate off by 2.2-fold (0.33 log units), on the low side, within the range that was stated.
By their numbers in this assay, from the lowest: compound 2; then compounds 3 and 4 (each within the scatter of the next). At a limit, above all of these: compound 1.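

In this assay, the exchange of phenyl for bromo on this aromatic carbon, para to a large group, gave a 1.0-fold higher number from compound 3 to compound 4 (0.02 log units; within the scatter), so the much larger ring left the read-out unmoved at this position. A second bromo-to-hydrogen exchange, with the phenyl kept in place, gave a 2.9-fold higher number from compound 2 to compound 4 (0.46 log units; beyond the scatter), which shows that the lower number of compound 2 goes with its bromo and not with the phenyl alone. Nothing measured here explains either step.

On these data alone, how an amine or a carboxylic acid would read on the carbon that holds phenyl in compound 4 remains open. As far as these compounds go, it also remains open whether the bromo of compound 2 would have the same effect on a core without the phenyl.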